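The source may report more compounds than this note shows. Statements on the series, on what has been measured and on what is new or still open speak of the compounds shown alone.

Two compounds share one core and differ only in the group on a single oxygen of the saturated ring. Compound 1, `CCCSc1nc(N[C@@H]2C[C@H]2c2ccc(F)c(F)c2)c2nnn([C@@H]3C[C@H](OC(=O)OCC)[C@@H](O)[C@H]3O)c2n1`, gives 42.6% in a functional assay on the whole organism (strain Sprague-Dawley) for inhibition, with Rattus norvegicus as the target, with a stated time of 0.5 h, at a dose of 5 mg/kg by the oral route; on this read-out higher numbers stand for more inhibition at the one dose given (going by the name of the read-out) and lower numbers for less inhibition. Compound 2, `CCCSc1nc(N[C@@H]2C[C@H]2c2ccc(F)c(F)c2)c2nnn([C@@H]3C[C@H](OC(=O)c4ccccc4)[C@@H](O)[C@H]3O)c2n1`, gives 20.1% in this assay and so stands lowest of the two numbers, with compound 1 the nearer and higher neighbour. Compound 3, `CCCSc1nc(N[C@@H]2C[C@H]2c2ccc(F)c(F)c2)c2nnn([C@@H]3C[C@H](OCCOC(=O)C(C)(C)C)[C@@H](O)[C@H]3O)c2n1`, has not yet been measured. It differs from compound 2 by 2-(((tert-butyl)carbonyl)oxy)ethyl in place of benzoyl on an oxygen on a saturated carbon. For the measured compounds named here, no measured step covers this kind of change; the one step seen, a number 22.5 percentage points lower from compound 1 to compound 2 (beyond the scatter), came with phenyl in place of ethoxy on a carbonyl carbon and shows only that what sits on this oxygen can move the read-out by a modest amount. Compound 3 is therefore expected to shift by a number 11.9 percentage points higher from compound 2 to compound 3 (beyond the scatter), upward, with wide uncertainty. The estimate for compound 3 in this assay is 32%, between 8% and 56%.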

Compound 3, a percentage reported as inhibition, in the whole organism at one dose (the size of the read-out at that dose, not a potency): 46.1%
Compound 3: middle estimate off by 14.1 percentage points, on the low side; low and high end bracket the measured number.
By their numbers in this assay, from the lowest: compound 2; then compounds 1 and 3 (each within the scatter of the next).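

In this assay, replacing benzoyl with the ring-free 2-(((tert-butyl)carbonyl)oxy)ethyl on this oxygen gives a number 26 percentage points higher from compound 2 to compound 3 (beyond the scatter), so the read-out at this place can rise as well as fall. For the compounds shown here, the change from ethoxycarbonyl to the same group gives a number 3.5 percentage points higher from compound 1 to compound 3 (within the scatter), so these two differently built groups are not separated, and among the three compounds only benzoyl, the one group with an aromatic ring, stands apart. The data offer no measured property that accounts for this.

Going by these compounds, whether the lower number goes with the aromatic ring itself remains open, and cyclohexanecarbonyl on this oxygen would test that directly. Also open, on these data alone, is how a group carrying an amine, or a longer chain ending in a carboxylic acid, would read at this place.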